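A few compounds are considered here, and "the series" means these few. Any claim that something is new, unique, unknown or untested is made for them only; others in the source may bear on it.

Compound 1, `O=C(COCc1ccccc1)N1CCN(c2ccc(Cl)cc2Cl)CC1`, gives 1000 nM in a functional assay on HEK293 cells for positive allosteric modulation of metabotropic glutamate receptor 5 (Homo sapiens), read by FLIPR and calcium flux (a lower number here means that less compound is needed, a higher number that more compound is needed for the effect), and among the three measured compounds it stands highest. Compound 2, `O=C(COCc1ccccc1)N1CCN(c2ccc(F)cc2F)CC1`, gives 300 nM, and compound 3, `O=C(COCc1ccccc1)N1CCN(c2ccc(F)cc2Cl)CC1`, gives 270 nM. The measured steps are a 3.3-fold lower number from compound 1 to compound 2 (0.52 log units; beyond the scatter) and a 3.7-fold lower number from compound 1 to compound 3 (0.57 log units; beyond the scatter), while a 1.1-fold lower number from compound 2 to compound 3 (0.05 log units; within the scatter).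

Compound 4, `O=C(CSc1ccccc1)N1CCN(c2ccc(Cl)cc2Cl)CC1`, differs from compound 1 at the other end of the molecule: phenylsulfanyl in place of benzyloxy on a saturated chain carbon bound to a carbonyl carbon. Every measured step concerns the halogens on the aryl ring attached to the amine nitrogen in the ring, and none touches the group on the saturated chain carbon bound to the carbonyl carbon. Within the data shown here, no measured step therefore bears on this change, and the data give no direction for it. With the halogen pattern of compound 1 kept, the number for compound 4 is taken as an expectation around the number of compound 1, with a wide range to reflect that nothing measured supports it.

Compound 4 is thus expected to give 1000 nM in this assay, with a range from 300 nM to 3000 nM. The step of no change at the digits printed from compound 1 to compound 4 (within the scatter) that this estimate means is expected to stay within the scatter.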

Compound 4, half-maximal effective concentration: > 25000 nM
Compound 4: only a limit was reported; the forecaster's own chance of this, stated with the estimate: 10%; middle value at least 25-fold (1.39 log units) from the limit.
By their numbers in this assay, from the lowest: compounds 3 and 2 (each within the scatter of the next); then compound 1. At a limit, above all of these: compound 4.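

Compound 4 is reported in this assay only as a limit: the limit of > 25000 nM in this assay, at which 1 of the 4 values shown sits.

Putting phenylsulfanyl in place of benzyloxy on a saturated chain carbon bound to a carbonyl carbon, with the rest of the molecule kept, gives an at least 25-fold higher number from compound 1 to compound 4 (1.39 log units; beyond the scatter). Among these compounds, this shows that the group at this position, which no earlier step touched, cannot be exchanged freely in this assay, even though the count of hydrogen-bond donors and acceptors and the net charge stay the same. The halogen changes on the aryl ring give smaller steps, such as a 3.7-fold lower number from compound 1 to compound 3 (0.57 log units; beyond the scatter), so in these compounds this single change at the other end of the molecule weighs more than any halogen change.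

The compounds shown do not tell whether the result follows from sulfur replacing oxygen or from the loss of the chain carbon, and a benzylsulfanyl or a phenoxy group on the same carbon would separate the two. Also open, going by these compounds, is whether the halogen patterns of compound 2 and compound 3 would give a different outcome with phenylsulfanyl at this position.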